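Aryl ether variation on the shared core

The source may hold more compounds than are shown below. What is called first, only, known or untested is meant among the compounds shown, and "the series" means these compounds.

Compound 3 `Cc1c(C)c2c(c(C)c1OCc1ccccc1)CCC(C)(COc1ccc(/C=C3\SC(=O)NC3=O)cc1)O2` gives the lowest of the three numbers measured in a functional assay on MCF7 cells (Homo sapiens), tested at 5 uM (on this read-out higher numbers stand for a weaker effect at the one concentration tested and lower numbers for a stronger effect), at 42%. Compound 1 `CC(C)=CCOc1c(C)c(C)c2c(c1C)CCC(C)(COc1ccc(/C=C3\SC(=O)NC3=O)cc1Br)O2` stands higher, at 84%, and compound 2 `Cc1c(C)c2c(c(C)c1OC(=O)CCC(=O)O)CCC(C)(COc1ccc(/C=C3\SC(=O)NC3=O)cc1)O2` highest, at 98%. Among the compounds with values here, the only single-point step measured so far, a number 56 percentage points lower from compound 2 to compound 3 (beyond the scatter), is large. Compound 4 `CC(C)=CCOc1c(C)c(C)c2c(c1C)CCC(C)(COc1ccc(/C=C3\SC(=O)NC3=O)cc1)O2` differs from compound 3 by 2-methylprop-1-en-1-yl in place of phenyl on a saturated chain carbon bound to an oxygen on an aromatic ring. Within the data shown here, no measured step bears directly on this change; compound 1 carries the same (3-methylbut-2-en-1-yl)oxy group together with a bromine and stands well above compound 3, so a rise beyond the scatter is expected, a number 23 percentage points higher from compound 3 to compound 4 (beyond the scatter), though smaller than the gap to compound 1 because compound 1 also carries the bromine at 84%. Compound 4 is estimated at 65%, within a range from 40% to 90%.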

Compound 4, a percentage reported as activity, at one concentration (the size of the read-out at that concentration, not a potency): 21%
Compound 4: the middle estimate sits 44 percentage points above what was measured; measured number outside the range, below it.
By their numbers in this assay, from the lowest: compound 4; then compound 3; then compound 1; then compound 2.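

In this assay the aromatic ring is not required on the saturated chain carbon bound to the oxygen: with benzyl exchanged for 3-methylbut-2-en-1-yl, the series shows a number 21 percentage points lower from compound 3 to compound 4 (beyond the scatter) on this change. The ester comparison also extends to this second ether, with a number 77 percentage points lower from compound 2 to compound 4 (beyond the scatter) for 3-methylbut-2-en-1-yl in place of (2-carboxyethyl)carbonyl. The high number of compound 1 does not belong to the ether alone, since hydrogen in place of bromo gives a number 63 percentage points lower from compound 1 to compound 4 (beyond the scatter) with that ether unchanged.

No measurement available explains these steps. Still open, on these data alone, is whether a saturated 3-methylbutyl chain or a chain ending in an amine on this oxygen keeps the read-out as low.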